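This account rests on a few compounds, and the source may have more. Where it says the series, first, only, none or still open, it means among the compounds named here.

Of the compounds shown here, two with a shared core have been measured. Compound 1 `CCCCN(CC)c1nc(C)nc2c1nnn2-c1c(C)cc(C)nc1C` in an in vitro assay on 293-EBNA cells for binding affinity to corticotropin-releasing factor receptor 1 (Homo sapiens) (on this read-out higher numbers stand for weaker inhibition and lower numbers for stronger inhibition), gives 65 nM. Compound 2 `CCCCN(CC)c1nc(C)nc2c1nnn2-c1c(Br)cc(OC)cc1OC` in this assay gives 3 nM. Of the two numbers, compound 2 holds the lower one, and its nearest neighbour is compound 1, whose number sits well above it, a gap beyond the usual scatter of repeated measurements. Compound 3 `CCCCN(CC)c1nc(C)nc2c1nnn2-c1c(Cl)cc(OC)cc1OC` is the next compound to be measured in this assay. It differs from compound 2 in a single place: chloro in place of bromo on an aromatic carbon. No step between two measured compounds of this kind exists among the numbers shown, so there is nothing from which to read off the size of such an exchange on this core. From the structures alone, the step in this assay from compound 2 to compound 3 is expected to be small, either within the scatter or a modest move toward a higher number, so that compound 3 is expected to stay close to compound 2. Compound 3 is therefore estimated at 5 nM, with a range from 1.5 nM to 15 nM. The step from compound 2 to compound 3 that this estimate means is a 1.7-fold higher number from compound 2 to compound 3 (0.22 log units; within the scatter).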

Compound 3, inhibition constant: 4.4 nM
Compound 3: the middle estimate sits 1.1-fold (0.06 log units) above what was measured; measured number inside the range.
By their numbers in this assay, from the lowest: compounds 2 and 3 (each within the scatter of the next); then compound 1.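

In this assay, chloro in place of bromo on the aromatic carbon that stands ortho to a large group and meta to two methoxy groups gives a 1.5-fold higher number from compound 2 to compound 3 (0.17 log units; within the scatter), the first step measured between two compounds of this series that differ in one place. It shows that, at this place on the shared core, bromo is not needed to keep the number where compound 2 has it, since the two halogens cannot be told apart on this read-out. No measurement bears on why the two halogens read alike, and this single pair offers no basis for any explanation.

The compounds shown leave open how much else this place accepts, since only two halogens appear there and nothing yet tells how fluoro, iodo, methyl, a nitrile or a plain hydrogen would read. They also leave open whether the exchange of bromo for chloro would read the same if the two methoxy groups were replaced by ethoxy groups, or if the amine on the shared core carried a longer chain.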